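This account rests on a few compounds, and the source may have more. Where it says the series, first, only, none or still open, it means among the compounds named here.

Compound 1 `COc1ccccc1C(=O)Nc1nnc(SCC(=O)Nc2ccc(Br)cn2)s1` gives in a functional assay on HeLa cells (Homo sapiens) for antiproliferative activity, read by MTT assay, with a stated time of 48 h (a lower number here means a stronger inhibitor, a higher number a weaker inhibitor), the limit > 80000 nM.
Compound 2 `COc1ccccc1C(=O)Nc1nnc(SCC(=O)Nc2ccc(C)cn2)s1` gives in this assay the limit > 80000 nM.
Compound 3 `COc1ccccc1C(=O)Nc1nnc(SCC(=O)Nc2c(C)ccnc2Cl)s1` gives in this assay the limit > 80000 nM.

Each of these values is a limit of the assay, not a measured number. In this assay all three compounds sit at the same limit, (the limit of > 80000 nM in this assay, at which 3 of the 3 values shown sit), so compound 1 has no position on a scale beyond that limit. The three comparisons among the measured compounds, a step that the two limits leave unreadable from compound 1 to compound 2, a step that the two limits leave unreadable from compound 1 to compound 3 and a step that the two limits leave unreadable from compound 2 to compound 3, each exchange the group on an amide-type nitrogen. None of them can be read: both of their end points sit at the limit.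

Compound 4 `O=C(CSc1nnc(NC(=O)CCl)s1)Nc1ccc(Br)cn1` departs from compound 1 at a different place: chloromethyl in place of 2-methoxyphenyl on a carbonyl carbon. Among the compounds with values here, no measured step touches the carbonyl carbon, so no measured step bears on this change, and neither size nor direction can be taken from the measured compounds. Within the data shown here, the expectation is therefore only that compound 4 stays in the region of the limit, with a wide range; the expected step of an at least 1.3-fold lower number from compound 1 to compound 4 (0.12 log units; that floor lies within the scatter) is little more than a placeholder. In this assay compound 4 is expected to give about 60000 nM, somewhere from 10000 nM to 300000 nM.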

Compound 4, half-maximal inhibitory concentration: 3400 nM
The estimate for compound 4 lay 18-fold (1.25 log units) above the measured number, outside the stated range (below it).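

Putting chloromethyl in place of 2-methoxyphenyl on a carbonyl carbon gives in this assay an at least 23-fold lower number from compound 1 to compound 4 (1.37 log units; beyond the scatter) and is the only step shown whose direction can be read. The three steps among compound 1, compound 2 and compound 3 cannot be read, so the exchanges on the amide-type nitrogen showed no position in this series that moves the number, whereas this change on the carbonyl carbon takes a compound clear of the limit. The printed step is a floor and not a full size, because compound 1 sits at a limit of the assay: the limit of > 80000 nM in this assay, at which 3 of the 4 values shown sit.

The change removes a six-membered aromatic ring and brings in a chlorine atom in a single move, so the compounds shown cannot tell which of the two matters, and a plain methyl or a bromomethyl on the same carbonyl carbon would help to separate them. Also open, going by these compounds, is whether chloromethyl would have a similar effect when the bromopyridine of compound 4 is replaced by the 5-methylpyridin-2-yl of compound 2 or the 2-chloro-4-methylpyridin-3-yl of compound 3.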